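The compounds below may be only part of what the source reports. "The series", "measured", "known", "first", "only" and "open" are said of these compounds alone.

Compound 1 `COc1ccc2cc([C@H](C)c3nnc(SCc4ccccc4)n3-c3ccc(Cl)cc3)ccc2c1` is the starting point of this account. In a functional assay on DU-145 cells (Homo sapiens) for cytotoxicity, read by MTT assay (on this read-out lower numbers stand for stronger inhibition and higher numbers for weaker inhibition), compound 1 gives 35800 nM, the lowest of the two plain numbers in this set. Its nearest neighbour is compound 3 `COc1ccc2cc([C@H](C)c3nnc(SCc4c(C)cc(C)cc4C)n3-c3cccc(Cl)c3)ccc2c1`, which in this assay gives 93300 nM, a gap beyond the usual scatter. Compound 2 `COc1ccc(CSc2nnc([C@@H](C)c3ccc4cc(OC)ccc4c3)n2-c2ccc(F)cc2)cc1` stands apart: in this assay compound 2 reaches only a limit of the assay, <= 400000 nM, and nothing more is known of it than that (the limit of <= 400000 nM in this assay, at which 1 of the 3 values shown sits).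

The step under study leads from compound 1 to compound 4 `COc1ccc2cc([C@H](C)c3nnc(SCc4ccc(Cl)cc4)n3-c3ccc(Cl)cc3)ccc2c1`. The two structures differ in one place: chloro in place of hydrogen on an aromatic carbon. Within the data shown here, no measured pair in this set shows the effect of such a change on its own, so the expectation rests on compound 1 alone. With the chloro entering on the benzyl group while the rest of the molecule stays as in compound 1, the step is expected to be small, at most a modest gain in potency, and quite possibly no change beyond the scatter of this assay.

On that basis compound 4 is estimated at 28000 nM, within a range of 10000 nM to 80000 nM. This estimate corresponds to an expected step of a 1.3-fold lower number from compound 1 to compound 4 (0.11 log units; within the scatter).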

Compound 4, half-maximal inhibitory concentration: 109000 nM
Compound 4: middle estimate off by 3.9-fold (0.59 log units), on the low side; the whole stated range lies below it.
By their numbers in this assay, from the lowest: compound 1; then compounds 3 and 4 (each within the scatter of the next).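

In this assay the benzyl group of compound 1 proves sensitive to substitution: the change to 4-chlorobenzyl gives a 3.0-fold higher number from compound 1 to compound 4 (0.48 log units; beyond the scatter) and so moves towards weaker inhibition, by more than the scatter. Among these compounds, this is the only comparison in the set that isolates one place, since compound 2 and compound 3 each differ from compound 1 in more than one, and it shows that a single chlorine atom on an aromatic carbon, para to a large group, is enough to shift the read-out. Nothing in the data shown bears on why the step goes in this direction.

Going by these compounds, what remains open is whether this loss is particular to chloro or would follow from any group on that carbon, such as a nitrile, an amine or a carboxylic acid. On these data alone, it is also open whether the same step would hold with the 4-chlorophenyl group on the core replaced by another group, or whether moving the chloro to another carbon of the benzyl ring would change its size.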